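Acetyl for Fluoro on the Anilide: Cytotoxicity Outlook

The source may report more compounds than this note shows. Statements on the series, on what has been measured and on what is new or still open speak of the compounds shown alone.

compound 1 `Cc1nc(C(NC(=O)C(=O)Nc2ccc(F)cc2)C2CCCCN2)sc1CCO`: > 88000 nM
compound 2 `Cc1nc(C(NC(=O)C(=O)Nc2ccc(Cl)cc2)C2CCCCN2C)sc1CCO`: 36000 nM

In an ADME assay on TZM-b1 cells (Homo sapiens) for cytotoxicity, read by XTT assay, with a stated time of 3 days (a higher number here means that more compound is tolerated, a lower number that less compound is tolerated), compound 1 gives > 88000 nM, which is a limit of the assay rather than a number (the limit of > 88000 nM in this assay, at which 1 of the 2 values shown sits). Compound 2 differs from compound 1 in more than one place, so its value stands on its own without a step to compare. Going by the values given here, compound 3 `CC(=O)c1ccc(NC(=O)C(=O)NC(c2nc(C)c(CCO)s2)C2CCCCN2)cc1` differs from compound 1 by acetyl in place of fluoro on an aromatic carbon; no measured pair shows this change. The change is expected to shift this assay by no more than the usual scatter, so an at least 1.1-fold lower number from compound 1 to compound 3 (0.04 log units; that floor lies within the scatter) is the estimated step. Compound 3 is accordingly expected at 80000 nM, with a range from 30000 nM to 200000 nM.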

Compound 3, half-maximal cytotoxic concentration: > 77300 nM
Compound 3: only a limit was reported; the forecaster's own chance of this, stated with the estimate: 50%; the middle value is on the limit's open side.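

In this assay compound 1 reads > 88000 nM and this is a limit. Compound 3 also reads as a limit (> 77300 nM), so no step can be read between them. Still open, going by these compounds, is whether acetyl in place of fluoro on an aromatic carbon changes this read-out at all.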